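This account rests on a few compounds, and the source may have more. Where it says the series, first, only, none or still open, it means among the compounds named here.

Measured so far:
compound 1 `O=C(Nc1ccc(Oc2ccnc3[nH]ccc23)c(F)c1)c1cc(-c2ccccc2)ncn1` gives 40 nM
compound 2 `O=C(Nc1ccc(Oc2ccnc3[nH]ccc23)c(F)c1)c1cc(-c2ccc(Cl)cc2)ncn1` gives 3200 nM

In a functional assay on PC-3 cells (Homo sapiens) for cytotoxicity, read by MTT assay, with a stated time of 72 h (a higher number here means a weaker inhibitor, a lower number a stronger inhibitor), compound 2 holds the highest of the two numbers, and its nearest neighbour is compound 1. Going by the values given here, the one step that bears on the next change is an 80-fold higher number from compound 1 to compound 2 (1.90 log units; beyond the scatter), a large shift from a single chloro placed on the six-membered aromatic ring of carbon only. Compound 3 `Cc1ccc(-c2cc(C(=O)Nc3ccc(Oc4ccnc5[nH]ccc45)c(F)c3)ncn2)cc1` differs from compound 2 by methyl in place of chloro on an aromatic carbon, so one small group replaces another at the same place. Compound 3 is therefore expected to stay near compound 2, an estimated step of a 2.1-fold lower number from compound 2 to compound 3 (0.33 log units; beyond the scatter), within the scatter. For compound 3 in this assay the estimate is 1500 nM, ranging from 300 nM to 8000 nM.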

Compound 3, half-maximal inhibitory concentration: 24900 nM
Compound 3: the middle estimate sits 17-fold (1.22 log units) below what was measured, outside the stated range (above it).
By their numbers in this assay, from the lowest: compound 1; then compound 2; then compound 3.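

In this assay, methyl and chloro are not interchangeable on this aromatic carbon, though each adds one heavy atom: the swap gives a 7.8-fold higher number from compound 2 to compound 3 (0.89 log units; beyond the scatter). Hydrogen remains far better than either group here, with methyl giving a 620-fold higher number from compound 1 to compound 3 (2.79 log units; beyond the scatter), a larger loss than chloro's an 80-fold higher number from compound 1 to compound 2 (1.90 log units; beyond the scatter). Nothing available explains this difference.

As far as these compounds go, whether any group on this carbon can match hydrogen stays open. So does how a methoxy group or an amine would compare there.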